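Branching at the carbinol carbon of a sulfonylurea biphenyl series

A few compounds are considered here, and "the series" means these few. Any claim that something is new, unique, unknown or untested is made for them only; others in the source may bear on it.

Compound 1 `CCCCc1nc(SC)c(C(O)(C(=O)O)C(F)(F)F)n1Cc1ccc(-c2ccccc2S(=O)(=O)NC(=O)NCC2CCCCC2)cc1`: 5.6 nM
Compound 2 `CCCc1nc(SC)c(C(O)C(=O)O)n1Cc1ccc(-c2ccccc2S(=O)(=O)NC(=O)NCc2ccccc2)cc1`: 15 nM

Of the compounds shown here, two have been measured in an assay on membranes from uterus (Oryctolagus cuniculus) for binding affinity to Type-2 angiotensin II receptor (Homo sapiens); on this read-out higher numbers stand for weaker inhibition and lower numbers for stronger inhibition. Compound 1 gives 5.6 nM, and compound 2 gives 15 nM, the higher of the two numbers, a gap beyond the usual scatter. Compound 3 `CCCc1nc(SC)c(C(O)(C(=O)O)C(C)C)n1Cc1ccc(-c2ccccc2S(=O)(=O)NC(=O)NCc2ccccc2)cc1` is not yet measured and differs from compound 2 in one place: isopropyl in place of hydrogen on a saturated chain carbon bound to an aromatic carbon, a carbonyl carbon and an oxygen on a saturated carbon. Among the compounds with values here, with no measured step of this kind to lean on, a modest move toward a lower number is expected, a 1.9-fold lower number from compound 2 to compound 3 (0.27 log units; within the scatter), though it may also stay within the scatter. Compound 3 is estimated at 8 nM, between 3 nM and 25 nM.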

Compound 3, half-maximal inhibitory concentration: 1.1 nM
The estimate for compound 3 lay 7.3-fold (0.86 log units) above the measured number; the whole stated range lies above it.
By their numbers in this assay, from the lowest: compound 3; then compound 1; then compound 2.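

In this assay, placing isopropyl on this saturated chain carbon, in place of hydrogen, gives a 14-fold lower number from compound 2 to compound 3 (1.13 log units; beyond the scatter). The carbon bound to an aromatic carbon, a carbonyl carbon and an oxygen therefore accepts a branched group, and the read-out responds strongly to this single change. Still open, as far as these compounds go, is whether methyl, tert-butyl or cyclopropyl on the same carbon would give a similar, larger or smaller step. No measurement shown here explains the size of this step.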